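One Aromatic Group Exchanged on a Carbonyl Carbon

This account rests on a few compounds, and the source may have more. Where it says the series, first, only, none or still open, it means among the compounds named here.

Measured so far in an ADME assay on microsomes from liver (Homo sapiens) for metabolic stability, read by LC-MS, with a stated time of 30 min, tested at 1 uM (on this read-out higher numbers stand for a more stable compound and lower numbers for a less stable compound), for two compounds
Compound 1 `O=C(NCc1ccc(S(=O)(=O)N2CCCCC2)cc1)c1ccn2ccnc2c1` with "not determined" (no result reported) as its entry
Compound 2 `O=C(NCc1ccc(S(=O)(=O)N2CCCCC2)cc1)c1ccc2nc[nH]c2c1` with 53% as its entry

Going by the values given here, compound 2 at 53% holds the only number in this assay so far, so it cannot yet be ranked against another compound. The change to compound 3 `O=C(NCc1ccc(S(=O)(=O)N2CCCCC2)cc1)c1cc2ccncc2o1` is a group of 9 heavy atoms (7 carbon, 1 nitrogen, 1 oxygen; one five-membered aromatic ring with 1 hetero atom, one six-membered aromatic ring with 1 hetero atom) in place of a group of 9 heavy atoms (7 carbon, 2 nitrogen; one five-membered aromatic ring with 2 hetero atoms, one six-membered aromatic ring of carbon only), on a carbonyl carbon and it sits on a carbonyl carbon. Among the compounds with values here, no measured step is available as a guide, so no step beyond the usual scatter is expected, in either direction. The estimated move is a number 5 percentage points lower from compound 2 to compound 3 (within the scatter) in this read-out. Compound 3 is expected at 48% within a range from 22% to 75% once it is measured.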

Compound 3, percent of the compound remaining: 56%
For compound 3 the middle estimate is 8 percentage points below the measured one; low and high end bracket the measured number.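

In this assay, the exchange of the 1H-benzimidazol-6-yl group on the carbonyl carbon gives a number 3 percentage points higher from compound 2 to compound 3 (within the scatter), the first step read at this position. Compound 2 and compound 3 therefore cannot be told apart on this read-out, although the entering group carries 0 hydrogen-bond donors and the leaving group 1. Nothing at hand speaks to the cause of this result.

Compound 1 offers no number, so its group stays unplaced. Going by these compounds, whether a plain phenyl ring or a saturated morpholine ring on this carbonyl carbon would hold the same level remains open.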